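A few compounds are considered here, and "the series" means these few. Any claim that something is new, unique, unknown or untested is made for them only; others in the source may bear on it.

Compound 1 `COCn1c(CC(COCc2ccccc2)COCc2ccccc2)cc(=O)[nH]c1=O` and compound 2 `COCn1c(CC(COCc2ccccc2)COCc2ccccc2)c(C)c(=O)[nH]c1=O` share one core. In a functional assay on SW-620 cells (Homo sapiens) for antiproliferative activity, read by MTT assay, with a stated time of 72 h (on this read-out lower numbers stand for stronger inhibition and higher numbers for weaker inhibition), compound 2 gives 72100 nM. Compound 1 reaches only a limit in this assay, > 100000 nM. The step of an at least 1.3-fold lower number from compound 1 to compound 2 (0.14 log units; that floor lies within the scatter) corresponds to methyl in place of hydrogen on an aromatic carbon. Compound 3 `O=c1cc(CC(O)COCc2ccccc2)[nH]c(=O)[nH]1` is built on another core; the difference between the two cores is not broken down here. In this assay compound 3 likewise gives only a limit, > 100000 nM. Compound 4 `Cc1c(CC(O)COCc2ccccc2)[nH]c(=O)[nH]c1=O` arises from compound 3 by the same kind of change, (methyl in place of hydrogen on an aromatic carbon); the place differs in that on compound 1 it is also meta to a methoxymethyl group (3 heavy atoms), which compound 3 does not carry. Two of the three values sit at the limit of > 100000 nM in this assay, at which 2 of the 3 values shown sit. The estimated step of a number no higher from compound 3 to compound 4 (the limit leaves the size open) rests on an at least 1.3-fold lower number from compound 1 to compound 2 (0.14 log units; that floor lies within the scatter), which lies within the scatter. Compound 4 is therefore expected near 100000 nM, between 40000 nM and 300000 nM.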

Compound 4, half-maximal inhibitory concentration: > 100000 nM
Compound 4 gave a limit, no number (the forecaster's own chance of this, stated with the estimate: 60%); the middle value sits exactly at the limit.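

Within the data shown here, compound 3 and compound 4 both give only a limit in this assay, so no step between them can be read. The compounds shown leave open whether methyl in place of hydrogen on an aromatic carbon changes the read-out on the core of compound 3.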